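Aryl swap on the amide: compound 2 to compound 3

The compounds below may be only part of what the source reports. "The series", "measured", "known", "first", "only" and "open" are said of these compounds alone.

In a functional assay on T47D cells (Homo sapiens) for inhibition, read by CCK-8 assay, with a stated time of 72 h, tested at 1 uM (on this read-out higher numbers stand for more inhibition of growth at the one concentration tested and lower numbers for less inhibition of growth), compound 1 `Cc1cccc(NC(=O)C2(C(=O)Nc3ccc(Nc4ncc5cc(C(=O)N(C)C)n(C6CCCC6)c5n4)cc3)CC2)c1` gives 45.7% and compound 2 `CN(C)C(=O)c1cc2cnc(Nc3ccc(NC(=O)C4(C(=O)Nc5ccc(Cl)cc5)CC4)cc3)nc2n1C1CCCC1` gives 22.8%. Compound 2 thus holds the lower of the two numbers, with a gap beyond the scatter. Compound 3 `CN(C)C(=O)c1cc2cnc(Nc3ccc(NC(=O)C4(C(=O)Nc5cccc(F)c5)CC4)cc3)nc2n1C1CCCC1` is not yet measured. It has 3-fluorophenyl in place of 4-chlorophenyl on an amide-type nitrogen. Within the data shown here, one measured step bears on this change: a number 22.9 percentage points lower from compound 1 to compound 2 (beyond the scatter), beyond the scatter, for 4-chlorophenyl in place of 3-methylphenyl on the same nitrogen. Among the measured compounds shown here, compound 3 shares neither group with compound 1, and no fluorophenyl compound has been measured, so this is only a loose guide. A rise of part of that size is expected, and the estimated step is a number 13.2 percentage points higher from compound 2 to compound 3 (beyond the scatter). In this assay the estimate for compound 3 is 36%, with an expected range of 18% to 55%.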

Compound 3, percent growth inhibition at one concentration: -3.2%
For compound 3 the middle estimate is 39.2 percentage points above the measured one; the measured number lies below the stated range.
By their numbers in this assay, from the lowest: compound 3; then compound 2; then compound 1.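

Replacing 4-chlorophenyl with 3-fluorophenyl on the amide-type nitrogen gives a number 26 percentage points lower from compound 2 to compound 3 (beyond the scatter) in this assay and leaves compound 3 at -3.2% as the lowest of the three numbers. Fluoro in place of methyl on an aromatic carbon gives a number 48.9 percentage points lower from compound 1 to compound 3 (beyond the scatter) as the largest step shown, so this one aromatic substituent strongly changes the read-out. The 3-methylphenyl and 3-fluorophenyl compounds sit at opposite ends, with the 4-chlorophenyl compound between them, so the number in the group's name does not sort these three compounds on its own.

Open, from the compounds shown here alone, is whether 3-chlorophenyl, 3-methoxyphenyl or unsubstituted phenyl on this nitrogen would sit nearer compound 1 or compound 3. No measured property is at hand to account for these steps.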